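Alkyl phosphate dithiocarbamates on MCF7 cells: chain shortening

This account rests on a few compounds, and the source may have more. Where it says the series, first, only, none or still open, it means among the compounds named here.

Measured compounds:
compound 1 `CCCCCCCCCCOP(=O)(O)OCCSC(=S)N1CCN(C)CC1`: 99600 nM
compound 2 `CCCCCCCCOP(=O)(O)OCCSC(=S)N1CCN(C)CC1`: 46000 nM
compound 3 `CCCCCCCCOP(=O)(O)OCCSC(=S)N1CCCCCC1`: 78000 nM

In a functional assay on MCF7 cells (Homo sapiens) for inhibition, read by MTT assay, with stated times of 18 h and 4 h (a lower number here means a stronger inhibitor, a higher number a weaker inhibitor), compound 1 gives 99600 nM and compound 2 gives 46000 nM. The change between them is hydrogen in place of ethyl on a saturated chain carbon, eight bonds along the chain from an oxygen on an unsaturated carbon and it made a 2.2-fold lower number from compound 1 to compound 2 (0.34 log units; beyond the scatter). Compound 3 gives 78000 nM in this assay; the step of a 1.7-fold higher number from compound 2 to compound 3 (0.23 log units; within the scatter) lies within the scatter. The difference between the core of compound 1 and the core of compound 3 is not broken down here.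

Compound 4 `CCCCCCOP(=O)(O)OCCSC(=S)N1CCCCCC1` is not yet measured. It differs from compound 3 by hydrogen in place of ethyl on a saturated chain carbon, six bonds along the chain from an oxygen on an unsaturated carbon. This is the same kind of change as from compound 1 to compound 2, but not the same: there the place was eight bonds along the chain from the oxygen, here it is six bonds along the chain. Resting on a 2.2-fold lower number from compound 1 to compound 2 (0.34 log units; beyond the scatter), a step of similar size is expected, a 1.7-fold lower number from compound 3 to compound 4 (0.24 log units; within the scatter). Compound 4 is thus estimated at 45000 nM in this assay, expected between 20000 nM and 120000 nM.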

Compound 4, half-maximal inhibitory concentration: 55000 nM
Compound 4: the middle estimate sits 1.2-fold (0.09 log units) below what was measured; measured number inside the range.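

In this assay, hydrogen in place of ethyl on a saturated chain carbon, six bonds along the chain from an oxygen on an unsaturated carbon, gives a 1.4-fold lower number from compound 3 to compound 4 (0.15 log units; within the scatter). Set beside the earlier step, the change carries from one core to the other with no difference in size that can be told apart: the same change on two cores in this assay, a 2.2-fold lower number (0.34 log units; beyond the scatter) from compound 1 to compound 2 and a 1.4-fold lower number (0.15 log units; within the scatter) from compound 3 to compound 4, 1.5-fold (0.18 log units) apart, within the scatter of two such steps. This does not show a general trend with chain length: only the earlier step lies beyond the scatter, the two steps sit at different places on the chain, and only two cores are shown.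

Still open, from the compounds shown here alone, is how a shorter chain or a longer chain behaves on either core. Also open, going by these compounds, is whether a carboxylic acid in place of the phosphate, or an open-chain amine in place of azepan-1-yl, would fit the same picture.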